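The source may hold more compounds than are shown below. What is called first, only, known or untested is meant among the compounds shown, and "the series" means these compounds.

Among the measured compounds shown here, compound 2 `O=C(N/N=C/c1cccc(O)c1O)c1ccc(-c2nc3ccccc3s2)cc1` gives 11200 nM in an assay on isolated protein for inhibition of Maltase-glucoamylase (Homo sapiens), with a stated time of 15 min (a higher number here means a weaker inhibitor, a lower number a stronger inhibitor), the highest of the two numbers so far, though its nearest neighbour, compound 1 `COc1ccc(O)c(/C=N/NC(=O)c2ccc(-c3nc4ccccc4s3)cc2)c1`, gives 6500 nM, within the scatter of it. For the measured compounds named here, the one measured step, a 1.7-fold higher number from compound 1 to compound 2 (0.24 log units; within the scatter), is within the scatter. Compound 3 `COc1ccc(/C=N/NC(=O)c2ccc(-c3nc4ccccc4s3)cc2)c(O)c1` arises from compound 2 by 2-hydroxy-4-methoxyphenyl in place of 2,3-dihydroxyphenyl on a carbon with a double bond to nitrogen. Going by the values given here, since the only comparable change, swapping one hydroxy and methoxy pattern for a dihydroxy one, moved the number only within the scatter, no shift beyond the scatter is expected here either. For compound 3 the expected value is 8000 nM, with a range from 3500 nM to 18000 nM. The expected step is therefore a 1.4-fold lower number from compound 2 to compound 3 (0.15 log units; within the scatter), no more than the scatter.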

Compound 3, half-maximal inhibitory concentration: 6970 nM
The estimate for compound 3 lay 1.1-fold (0.06 log units) above the measured number; measured number inside the range.
By their numbers in this assay, from the lowest: compounds 1, 3 and 2 (each within the scatter of the next).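

In this assay, 2-hydroxy-4-methoxyphenyl on this carbon with a double bond to nitrogen cannot be told apart from either earlier group: a 1.6-fold lower number from compound 2 to compound 3 (0.21 log units; within the scatter) and a 1.1-fold higher number from compound 1 to compound 3 (0.03 log units; within the scatter) both stay within the scatter. Among the compounds shown here, the second step is the first comparison of two groups that each carry one hydroxy and one methoxy, 2-hydroxy-4-methoxyphenyl and 2-hydroxy-5-methoxyphenyl, and it shows no difference between them. No available evidence bears on this result. On these data alone, whether a phenyl carrying an amine or a carboxylic acid at this place would move the number beyond the scatter remains open.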